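A few compounds are considered here, and "the series" means these few. Any claim that something is new, unique, unknown or untested is made for them only; others in the source may bear on it.

Of the compounds shown here, two have been measured in an ADME assay on PC-3 cells (Homo sapiens) for cytotoxicity, read by WST assay, tested at 100 uM; a lower number here means less inhibition, a higher number more inhibition at the concentration tested (going by the name of the read-out). Compound 1 `O=C(Nc1cccc(CN2CCCC2)c1)C1CCCN(C(=O)c2cc(C(F)(F)F)cc(C(F)(F)F)c2)C1` gives 51%, while compound 2 `O=C(Nc1cccc(OCCc2ccccn2)c1)C1CCCN(C(=O)c2cc(C(F)(F)F)cc(C(F)(F)F)c2)C1` gives 5%, the lower of the two numbers, with the change a number 46 percentage points lower from compound 1 to compound 2 (beyond the scatter). Compound 3 `O=C(c1ccccc1)c1cccc(NC(=O)C2CCCN(C(=O)c3cc(C(F)(F)F)cc(C(F)(F)F)c3)C2)c1` has not yet been measured; it differs from compound 2 by benzoyl in place of 2-(pyridin-2-yl)ethoxy on an aromatic carbon. Going by the values given here, the one measured step shows that a change at this same position moved the read-out strongly, so a step beyond the scatter is plausible here too, though its direction is uncertain. For compound 3 the expected value in this assay is 20%, within 0% to 50%, meaning an expected step of a number 15 percentage points higher from compound 2 to compound 3 (beyond the scatter).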

Compound 3, a percentage reported as inhibition, at one concentration (the size of the read-out at that concentration, not a potency): 0%
Estimate against measurement, compound 3: 20 percentage points above; the measured number falls inside the stated range.
By their numbers in this assay, from the lowest: compounds 3 and 2 (each within the scatter of the next); then compound 1.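

In this assay, benzoyl in place of 2-(pyridin-2-yl)ethoxy gives a number 5 percentage points lower from compound 2 to compound 3 (within the scatter), so these two different groups, each carrying a six-membered aromatic ring, read alike at this position. Benzoyl in place of (pyrrolidin-1-yl)methyl gives a number 51 percentage points lower from compound 1 to compound 3 (beyond the scatter), so a second replacement of that group also produces a large step, and compound 1 stands apart among these three. Nothing measured here explains the difference. Still open, from the compounds shown here alone, is whether the higher reading belongs to the pyrrolidine ring or to amines more widely. An open-chain amine such as dimethylaminomethyl, or a carboxylic acid, at this position would test that.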